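This account rests on a few compounds, and the source may have more. Where it says the series, first, only, none or still open, it means among the compounds named here.

Of the compounds shown here, three built on one shared core have been measured in a functional assay for activation of Alpha-1A adrenergic receptor (Homo sapiens), read by calcium flux; a lower number here means that less compound is needed, a higher number that more compound is needed for the effect. Compound 1 `Cc1ncc(-c2ccccc2NCC2=NCCN2)o1` gives 110 nM. Compound 2 `Cc1ccc(-c2ccccc2NCC2=NCCN2)o1` gives 2.69 nM. Compound 3 `c1ccc(-c2ccccc2NCC2=NCCN2)nc1` gives 6.76 nM. Among these three numbers compound 3 stands second highest: the step of a 2.5-fold higher number from compound 2 to compound 3 (0.40 log units; beyond the scatter) is modest, while the step of a 16-fold lower number from compound 1 to compound 3 (1.21 log units; beyond the scatter) is large, as is a 41-fold lower number from compound 1 to compound 2 (1.61 log units; beyond the scatter). Each of these measured steps swaps one aromatic ring for another at the same position, and the spread of the outcomes shows that this group strongly shapes the result in this assay.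

Compound 4 `CO/N=C/c1ccccc1NCC1=NCCN1` has not yet been measured. Against compound 3 the difference is a group of 4 heavy atoms (2 carbon, 1 nitrogen, 1 oxygen; no ring) in place of a group of 6 heavy atoms (5 carbon, 1 nitrogen; one six-membered aromatic ring with 1 hetero atom), on an aromatic carbon. The entering group has no ring and carries one double bond outside aromatic rings, so this change reaches further than any measured step, all of which kept a ring in this place. Within the data shown here, the steps that bear on it, a 2.5-fold higher number from compound 2 to compound 3 (0.40 log units; beyond the scatter) and a 16-fold lower number from compound 1 to compound 3 (1.21 log units; beyond the scatter), ran from modest to large, and because a 16-fold lower number from compound 1 to compound 3 (1.21 log units; beyond the scatter) shows how sharply the number can rise when this group is altered, a higher number is expected for compound 4 in this assay. Compound 4 is therefore estimated at 50 nM, within a range from 8 nM to 300 nM, which would amount to an expected step of a 7.4-fold higher number from compound 3 to compound 4 (0.87 log units; beyond the scatter).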

Compound 4, half-maximal effective concentration: 51.3 nM
Beside the measured number, compound 4's estimate is 1.0-fold (0.01 log units) below it; the range from low to high includes it.
By their numbers in this assay, from the lowest: compound 2; then compound 3; then compound 4; then compound 1.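

The ring-free group of compound 4 still gives a measurable response in this assay, so an aromatic ring on this aromatic carbon is not a requirement for activation. It does not match the two best rings, though, with a 7.6-fold higher number from compound 3 to compound 4 (0.88 log units; beyond the scatter) and a 19-fold higher number from compound 2 to compound 4 (1.28 log units; beyond the scatter), yet the comparison turns around against the third ring, with a 2.1-fold lower number from compound 1 to compound 4 (0.33 log units; beyond the scatter). Having a ring here therefore does not by itself secure a low number, as the ring-free group falls between the rings of compounds 1 and 3, and nothing available explains why the groups rank in this order.

The compounds shown leave open which part of the entering group matters: a plain propyl chain at the same place would help separate the contribution of the oxygen and the double bond from that of simply having a short chain there. Also open, from the compounds shown here alone, is how far this position accepts other ring-free groups, such as a primary amine or a carboxylic acid, whose results could widen the picture well beyond these four compounds.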